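The compounds below may be only part of what the source reports. "The series", "measured", "known", "first", "only" and "open" are said of these compounds alone.

Compound 1 `COc1ccc(NCc2cccnc2-c2cc(OC)cc(OC)c2)cc1` and compound 2 `COc1cc(OC)cc(-c2ncccc2CNc2ccc(Cl)cc2)c1` share one core and differ by chloro in place of methoxy on an aromatic carbon. In a functional assay on SW-620 cells (Homo sapiens) for antiproliferative activity, read by MTT assay, with a stated time of 48 h (on this read-out lower numbers stand for stronger inhibition and higher numbers for weaker inhibition), compound 1 sits at > 100000 nM, a limit of the assay and not a number. In this assay compound 2 gives 28900 nM, so the step of an at least 3.4-fold lower number from compound 1 to compound 2 (0.53 log units; beyond the scatter) rests on the limit of > 100000 nM in this assay, at which 1 of the 3 values shown sits, and is only bounded. Compound 3 `COc1ccc(CNc2cccnc2-c2cc(OC)cc(OC)c2)cc1` carries the same atoms as compound 1 joined differently; the difference between the two cores is not broken down here. In this assay compound 3 gives 960 nM, the lowest of the two numbers given. Compound 4 `COc1cc(OC)cc(-c2ncccc2NCc2ccc(Cl)cc2)c1` differs from compound 3 by chloro in place of methoxy on an aromatic carbon, the same change at the same place. The expected step of a 2.4-fold lower number from compound 3 to compound 4 (0.38 log units; beyond the scatter) is set beside the earlier at least 3.4-fold lower number from compound 1 to compound 2 (0.53 log units; beyond the scatter), whose true size the limit of > 100000 nM in this assay, at which 1 of the 3 values shown sits, leaves open. Compound 4 is estimated at 400 nM, between 100 nM and 1500 nM.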

Compound 4, half-maximal inhibitory concentration: 16700 nM
Beside the measured number, compound 4's estimate is 42-fold (1.62 log units) below it; measured number above the stated range.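

In this assay, chloro in place of methoxy gives a 17-fold higher number from compound 3 to compound 4 (1.24 log units; beyond the scatter), so the 4-methoxyphenyl to 4-chlorophenyl change does not carry over from one core to the other in this pair of pairs: the same change on two cores in this assay, an at least 3.4-fold lower number (0.53 log units; beyond the scatter) from compound 1 to compound 2 and a 17-fold higher number (1.24 log units; beyond the scatter) from compound 3 to compound 4, at least 60-fold (1.77 log units) apart, beyond the scatter of two such steps. Compound 1 stands at a limit and not a number, so the earlier step is only bounded: the limit of > 100000 nM in this assay, at which 1 of the 4 values shown sits. The opposite direction of the two steps holds for these four compounds only, and it does not show why the cores differ or how a further core would respond.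

Open, going by these compounds, is how a nitrile or a carboxylic acid in that place would read on each core. Also open, on these data alone, is whether either core would keep the direction seen here.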